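Piperazine amide substituent swap at a fatty acid receptor agonist

The compounds below may be only part of what the source reports. "The series", "measured", "known", "first", "only" and "open" are said of these compounds alone.

Compound 1 `CC#CC(CC(=O)O)c1ccc(OCc2ccc(C(=O)N3CCN(C4CCCCC4)CC3)s2)cc1`: 820 nM
Compound 2 `CC#CC(CC(=O)O)c1ccc(OCc2ccc(C(=O)N3CCN(c4ccc(C(C)(C)C)cc4)CC3)s2)cc1`: 417 nM

Among the measured compounds shown here, in a functional assay on HEK293 cells for agonist activity at Free fatty acid receptor 1 (Homo sapiens), read by fluorescence and calcium flux (a higher number here means that more compound is needed for the effect, a lower number that less compound is needed), compound 2 gives 417 nM; the only other number is that of compound 1, and the step of a 2.0-fold lower number from compound 1 to compound 2 (0.29 log units; within the scatter) stays within the scatter. Compound 3 `CC#CC(CC(=O)O)c1ccc(OCc2ccc(C(=O)N3CCN(c4ccccc4F)CC3)s2)cc1` differs from compound 2 by 2-fluorophenyl in place of 4-(tert-butyl)phenyl on an amine nitrogen in a ring. For the measured compounds named here, the one measured step at this position, a 2.0-fold lower number from compound 1 to compound 2 (0.29 log units; within the scatter), did not move the number beyond the scatter, so for compound 3 no shift beyond the scatter is expected in this assay either, with the estimated step of a 1.4-fold higher number from compound 2 to compound 3 (0.16 log units; within the scatter). Compound 3 is therefore expected at about 600 nM, between 250 nM and 1500 nM.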

Compound 3, half-maximal effective concentration: 113 nM
The estimate for compound 3 lay 5.3-fold (0.73 log units) above the measured number; measured number below the stated range.
By their numbers in this assay, from the lowest: compound 3; then compounds 2 and 1 (each within the scatter of the next).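

In this assay the group on this amine nitrogen can move the number beyond the scatter, which the earlier step did not show: 2-fluorophenyl gives a 3.7-fold lower number from compound 2 to compound 3 (0.57 log units; beyond the scatter) and, against cyclohexyl, a 7.3-fold lower number from compound 1 to compound 3 (0.86 log units; beyond the scatter). Among these three compounds, an aromatic ring alone does not account for the change, since 4-(tert-butyl)phenyl and 2-fluorophenyl both carry one. No measurement here bears on the reason for the step. From the compounds shown here alone, it remains open whether the change belongs to the fluorine or to the loss of the tert-butyl group; plain phenyl or 2-chlorophenyl on the same nitrogen would help separate these.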